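A few compounds are considered here, and "the series" means these few. Any claim that something is new, unique, unknown or untested is made for them only; others in the source may bear on it.

Series notes. Compound 1 `O=C(/C=C\Nc1ccc(Cl)cc1)c1cn(-c2ccccc2)nc1-c1ccc(F)cc1` and compound 3 `COc1cc(-c2nn(-c3ccccc3)cc2C(=O)/C=C\Nc2ccc(Cl)cc2)cc(OC)c1OC` carry the same chloro-bearing ring; the difference between their two cores is not broken down here. In a functional assay on HT-29 cells (Homo sapiens) for antiproliferative activity, read by MTT assay, with a stated time of 48 h (on this read-out higher numbers stand for weaker inhibition and lower numbers for stronger inhibition), compound 1 gives 4600 nM. In this assay compound 3 gives 7680 nM, a value that sits within the scatter of compound 1, so no order is read between the two.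

Compound 2 `O=C(/C=C\Nc1ccc(C(F)(F)F)cc1)c1cn(-c2ccccc2)nc1-c1ccc(F)cc1` is compound 1 with the change (trifluoromethyl in place of chloro on an aromatic carbon). In this assay compound 2 reaches only a limit of the assay, > 50000 nM. That this is a limit rather than a number is marked by the limit of > 50000 nM in this assay, at which 1 of the 3 values shown sits. The step is an at least 10-fold higher number from compound 1 to compound 2 (1.03 log units; beyond the scatter), the one large movement seen so far in the set.

Compound 4 `COc1cc(-c2nn(-c3ccccc3)cc2C(=O)/C=C\Nc2ccc(C(F)(F)F)cc2)cc(OC)c1OC` is not yet measured. It is compound 3 with the change (trifluoromethyl in place of chloro on an aromatic carbon), the same change as between compound 1 and compound 2, at the same kind of position. The step in this assay is expected to be a 7.8-fold higher number from compound 3 to compound 4 (0.89 log units; beyond the scatter) because the earlier step was an at least 10-fold higher number from compound 1 to compound 2 (1.03 log units; beyond the scatter). Compound 4 is therefore estimated at 60000 nM, expected to fall between 20000 nM and 200000 nM, with a real chance that this assay returns only a limit and no number.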

Compound 4, half-maximal inhibitory concentration: > 50000 nM
Compound 4 was reported as a limit; the forecaster's own chance of this, stated with the estimate: 70%; the middle value is on the limit's open side.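

Carried onto the core of compound 3, trifluoromethyl in place of chloro again raises the number in this assay, giving an at least 6.5-fold higher number from compound 3 to compound 4 (0.81 log units; beyond the scatter), so the direction of the change is the same on both cores shown: the same change on two cores in this assay, an at least 10-fold higher number (1.03 log units; beyond the scatter) from compound 1 to compound 2 and an at least 6.5-fold higher number (0.81 log units; beyond the scatter) from compound 3 to compound 4; the limit leaves it open whether they differ

What this does not show is the size of the change on either core, so no claim can be made that the two cores respond alike or differently, as both trifluoromethyl compounds, compound 2 and compound 4, stand at a limit and not at a number: the limit of > 50000 nM in this assay, at which 2 of the 4 values shown sit.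

The step between compound 2 and compound 4 cannot be read, as both of its ends are limits, and the pair therefore says nothing about 3,4,5-trimethoxyphenyl against 4-fluorophenyl.

As far as these compounds go, the pattern rests on two pairs with a single replacement for chloro, so it remains open whether a nitrile, an amine or a carboxylic acid on the same aromatic carbon would stay close to the chloro compounds or also reach the limit. Also open, from the compounds shown here alone, is whether the change would act in the same direction on a third core, or in a cell line other than the one used here.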